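The source may report more compounds than this note shows. Statements on the series, on what has been measured and on what is new or still open speak of the compounds shown alone.

Values in an ADME assay on liver (Mus musculus, strain CD-1) for metabolic stability, read by LC-MS, using microsomes and NADPH, with a stated time of 5 min, tested at 1 uM (a lower number here means that the compound disappears faster, a higher number that the compound lasts longer), for the series so far
- compound 1 `COc1ncc(NC(=O)C(=O)c2cn(C(C)C)c3ccccc23)cn1` gives 0.0833 h
- compound 2 `COc1ccc(NC(=O)C(=O)c2cn(C(C)C)c3ccccc23)cn1` gives 0.0833 h
- compound 3 `CC(C)Oc1ccc(NC(=O)C(=O)c2cn(C(C)C)c3ccccc23)cn1` gives 1.1 h

Compound 2 is level with compound 1, and the two share the low end of the three numbers, with compound 3 well clear of them. Two measured steps are available. Exchanging 2-methoxypyrimidin-5-yl for 6-methoxypyridin-3-yl gives no change at the digits printed from compound 1 to compound 2 (within the scatter) and isopropyl in place of methyl on the oxygen gives a 13-fold higher number from compound 2 to compound 3 (1.12 log units; beyond the scatter) in this series.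

Compound 4 `COCC(C)(C)n1cc(C(=O)C(=O)Nc2ccc(OC)nc2)c2ccccc21` has methoxymethyl in place of hydrogen on a saturated chain carbon bound to an aromatic nitrogen and two saturated chain carbons, counted as methoxymethyl in place of hydrogen on a saturated chain carbon bound to an aromatic nitrogen and two saturated chain carbons and also readable as isopropyl to 1-(methoxymethyl)-1-methylethyl. Neither measured step touches that place, so both are only a rough guide. The isopropyl step is the sole measured move to a larger alkyl group and it went upward, so a smaller rise is expected here. The expected change is a 2.4-fold higher number from compound 2 to compound 4 (0.38 log units; beyond the scatter) in this assay as an estimate with wide uncertainty. For compound 4 the expected half-life is 0.2 h with an estimated range of 0.08 h to 0.6 h.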

Compound 4, half-life: 0.267 h
For compound 4 the middle estimate is 1.3-fold (0.13 log units) below the measured one; low and high end bracket the measured number.
By their numbers in this assay, from the lowest: compounds 1 and 2 (each within the scatter of the next); then compound 4; then compound 3.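

In this assay, among these compounds, the place on a saturated chain carbon bound to an aromatic nitrogen and two saturated chain carbons proves open to change, whereas the earlier steps touched only the group on the amide-type nitrogen: methoxymethyl in place of hydrogen there gives a 3.2-fold higher number from compound 2 to compound 4 (0.51 log units; beyond the scatter). This modest rise is smaller than a 13-fold higher number from compound 2 to compound 3 (1.12 log units; beyond the scatter), so the isopropyl on the oxygen remains the larger of the two measured gains. No measurement shown here explains the rise at the new place.

As far as these compounds go, whether the two rises add up when isopropyl on the oxygen and 1-(methoxymethyl)-1-methylethyl sit in one compound remains open. Also open, from the compounds shown here alone, is whether a tert-butyl group, an amine or a carboxylic acid at this place would shift the half-life in the same direction.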